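The source may report more compounds than this note shows. Statements on the series, on what has been measured and on what is new or still open speak of the compounds shown alone.

Working notes on the amide series. Among the measured compounds shown here, in a functional assay on Shh Light II cells for inhibition of Sonic hedgehog protein (Mus musculus), read by reporter gene assay, with a stated time of 48 h, in the presence of a further agent that is not named here (a higher number here means a weaker inhibitor, a lower number a stronger inhibitor), compound 1 `O=C(Nc1ccc(Cl)c(-c2nc3ccccc3[nH]2)c1)c1ccc(Cl)cc1` gives 224 nM, while compound 2 `COc1ccccc1C(=O)Nc1ccc(Cl)c(-c2nc3ccccc3[nH]2)c1` gives 876 nM; swapping the aryl on the carbonyl carbon produced a 3.9-fold higher number from compound 1 to compound 2 (0.59 log units; beyond the scatter), so compound 2 holds the higher of the two numbers, with compound 1 its only neighbour. Compound 3 `COc1ccc(C(=O)Nc2ccc(Cl)c(-c3nc4ccccc4[nH]3)c2)cc1` differs from compound 2 by 4-methoxyphenyl in place of 2-methoxyphenyl on a carbonyl carbon. For the measured compounds named here, the one measured step bears on the same carbonyl carbon and was modest; the change toward compound 3 is smaller still, a rearrangement of the same atoms. For compound 3 a mild move toward a lower number is expected, a 2.2-fold lower number from compound 2 to compound 3 (0.34 log units; beyond the scatter), giving an estimate of 400 nM with a range of 130 nM to 1200 nM.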

Compound 3, half-maximal inhibitory concentration: 117 nM
Compound 3: middle estimate off by 3.4-fold (0.53 log units), on the high side, and the stated range ends above it.
By their numbers in this assay, from the lowest: compounds 3 and 1 (each within the scatter of the next); then compound 2.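

On the carbonyl carbon, 4-methoxyphenyl in place of 2-methoxyphenyl gives a 7.5-fold lower number from compound 2 to compound 3 (0.87 log units; beyond the scatter), a larger step than a 3.9-fold higher number from compound 1 to compound 2 (0.59 log units; beyond the scatter), so rejoining the same atoms matters more here than the earlier aryl swap. Methoxy in place of chloro on an aromatic carbon gives a 1.9-fold lower number from compound 1 to compound 3 (0.28 log units; within the scatter), so 4-methoxyphenyl and 4-chlorophenyl are not told apart here. No measurement shown bears on the reason for the difference between 2-methoxyphenyl and 4-methoxyphenyl. Open, from the compounds shown here alone, is whether an amine, a carboxylic acid or a longer chain in place of the methoxy of compound 3 would keep the number as low.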